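This account rests on a few compounds, and the source may have more. Where it says the series, first, only, none or still open, it means among the compounds named here.

In a functional assay on DLD-1 cells (Homo sapiens) for cytotoxicity, read by resazurin assay, with a stated time of 48 h (a higher number here means that more compound is needed for the effect, a lower number that less compound is needed), compound 1 (`O=C(Nc1ccc(Sc2nc3ccccc3s2)c(Cl)c1)c1cccc(Br)c1O`) gives 22000 nM and compound 2 (`COc1ccc(S(=O)(=O)Nc2ccc3oc(-c4ccc(NS(=O)(=O)c5cc(F)ccc5OC)cc4)nc3c2)cc1`) gives 18000 nM, and these two values lie within the usual scatter of each other. Compound 3 (`COc1c(Br)cccc1C(=O)Nc1ccc(Sc2nc3ccccc3s2)c(Cl)c1`) differs from compound 1 by methyl in place of hydrogen on an oxygen on an aromatic ring, hydroxy to methoxy. Within the data shown here, no measured step shows this change, so this assay is expected to show no step beyond the scatter. The estimate means a step of a 1.4-fold higher number from compound 1 to compound 3 (0.13 log units; within the scatter) that is expected to stay inside the scatter. Compound 3 is estimated at 30000 nM with 10000 nM to 80000 nM as its expected range.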

Compound 3, half-maximal effective concentration: 10000 nM
Beside the measured number, compound 3's estimate is 3.0-fold (0.48 log units) above it, and the stated range covers the measured number.
By their numbers in this assay, from the lowest: compounds 3, 2 and 1 (each within the scatter of the next, the first and the last beyond it).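

In this assay, among these compounds, the change from hydroxy to methoxy gives a 2.2-fold lower number from compound 1 to compound 3 (0.34 log units; beyond the scatter) and is the first measured step at this position. The hydrogen on this oxygen is therefore not required for the effect, and methyl is accepted in its place. No available evidence accounts for the step. The compounds shown leave open whether a longer chain on this oxygen, such as ethoxy, or an amine in place of the hydroxy would move the number further. They also leave open whether the same change would give a similar step on a different core.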